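Sulfamate amides: furan-2-yl versus (dimethylamino)methyl on the side chain

The source may report more compounds than this note shows. Statements on the series, on what has been measured and on what is new or still open speak of the compounds shown alone.

Measured so far in an assay on HEK293 cells for inhibition of Steryl-sulfatase (Homo sapiens), tested at 1 uM; on this read-out higher numbers stand for a stronger effect at the one concentration tested and lower numbers for a weaker effect:
- compound 1 `NS(=O)(=O)Oc1ccc2c(c1)CN(C(=O)c1cccc(N3CCN(c4ncccn4)CC3)c1)CC2`: 24.4%
- compound 2 `NS(=O)(=O)Oc1ccc2c(c1)CN(C(=O)c1cccc(N(Cc3ccccc3)Cc3ccco3)c1)CC2`: 90.5%
- compound 3 `NS(=O)(=O)Oc1ccc2c(c1)CN(C(=O)c1ccc(N3CCC(N4CCCCC4)CC3)cc1)CC2`: 53.7%

Compound 2 holds the highest of the three numbers. The nearest, compound 3, sits well below it, beyond the scatter, and compound 1 lies furthest down, also beyond the scatter. No single-change pairs exist among these three, so the gaps between them cannot be tied to one group.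

Compound 4 `CN(C)CCN(Cc1ccccc1)c1cccc(C(=O)N2CCc3ccc(OS(N)(=O)=O)cc3C2)c1` has not yet been run in this assay. Against compound 2 the change is (dimethylamino)methyl in place of furan-2-yl on a saturated chain carbon bound to a nitrogen on an aromatic ring. The shared core and the benzyl arm on the aromatic nitrogen stay in place; only the second arm changes.

Among the compounds with values here, three compounds give no direct precedent for this swap. The two compounds carrying a saturated nitrogen-containing group on the aromatic ring, compound 1 at 24.4% and compound 3 at 53.7%, both fall short of compound 2. On that basis a downward step is expected for compound 4, estimated as a number 30.5 percentage points lower from compound 2 to compound 4 (beyond the scatter), likely beyond the scatter but uncertain in size. Compound 4 is therefore expected near 60%, within a range of 30% to 85%.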

Compound 4, a percentage reported as inhibition, at one concentration (the size of the read-out at that concentration, not a potency): 28.6%
Estimate against measurement, compound 4: 31.4 percentage points above, and the stated range ends above it.
By their numbers in this assay, from the lowest: compounds 1 and 4 (each within the scatter of the next); then compound 3; then compound 2.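

In this assay, within the data shown here, the second arm on the aromatic nitrogen is the first place where a single change can be read: (dimethylamino)methyl in place of furan-2-yl on a saturated chain carbon bound to a nitrogen on an aromatic ring gives a number 61.9 percentage points lower from compound 2 to compound 4 (beyond the scatter). Among these compounds, with the shared core and the benzyl arm unchanged, this arm alone carries a large part of the read-out at the one concentration tested, something the earlier compounds, with no single-change pair among them, could not show. No measurement in hand says why this step is so large.

The swap removes a ring and brings in an amine at once, and the compounds shown leave open which of the two goes with the lower number; a thiophen-2-yl or phenyl group in the furan-2-yl place would test the ring, while a plain propyl chain or a 2-(morpholin-4-yl)ethyl arm would test the chain and its amine. As far as these compounds go, whether one such step holds with a different arm in place of the benzyl group also stays open.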